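Working notes: methoxy additions and PC-3 cytotoxicity

This account rests on a few compounds, and the source may have more. Where it says the series, first, only, none or still open, it means among the compounds named here.

Measured compounds:
compound 1 `O=S(=O)(c1ccccc1)c1nc2ccccc2nc1Nc1ccccc1`: 590 nM
compound 2 `COc1ccc(Nc2nc3ccccc3nc2S(=O)(=O)c2ccccc2)cc1`: 1510 nM
compound 3 `COc1cc(Nc2nc3ccccc3nc2S(=O)(=O)c2ccc(F)cc2)cc(OC)c1`: 4530 nM

In a functional assay on PC-3 cells (Homo sapiens) for cytotoxicity, read by MTT assay, with a stated time of 72 h (a higher number here means a weaker inhibitor, a lower number a stronger inhibitor), compound 1 gives 590 nM and compound 2 gives 1510 nM. The change between them is methoxy in place of hydrogen on an aromatic carbon, and it made a 2.6-fold higher number from compound 1 to compound 2 (0.41 log units; beyond the scatter). Compound 3 gives 4530 nM in this assay; the difference between its core and that of compound 1 is not broken down here.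

Compound 4 `COc1cc(Nc2nc3ccccc3nc2S(=O)(=O)c2ccc(F)cc2)cc(OC)c1OC` is not yet measured. It differs from compound 3 by methoxy in place of hydrogen on an aromatic carbon. This is the same kind of change as from compound 1 to compound 2, but not the same: here the entering group sits ortho to two methoxy groups (2 heavy atoms each) as well as para to a large group, whereas in compound 2 it is only para to a large group.

For the measured compounds named here, the expectation for this assay rests on the one measured instance, a 2.6-fold higher number from compound 1 to compound 2 (0.41 log units; beyond the scatter), from compound 1 to compound 2; the step of a 1.7-fold higher number from compound 3 to compound 4 (0.22 log units; within the scatter) is estimated to be of similar direction. Compound 4 is therefore expected to give about 7500 nM, within 3000 nM to 18000 nM.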

Compound 4, half-maximal inhibitory concentration: > 50000 nM
Compound 4: a limit, no number; the forecaster's own chance of this, stated with the estimate: 15%; middle value at least 6.6-fold (0.82 log units) from the limit.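

In this assay compound 4 gives > 50000 nM which is a limit of the assay and not a number: the limit of > 50000 nM in this assay, at which 1 of the 4 values shown sits.
Methoxy in place of hydrogen on an aromatic carbon gives an at least 11-fold higher number from compound 3 to compound 4 (1.04 log units; beyond the scatter) so the direction of the earlier step holds here, but its size does not carry over from one core to the other: the same change on two cores in this assay, a 2.6-fold higher number (0.41 log units; beyond the scatter) from compound 1 to compound 2 and an at least 11-fold higher number (1.04 log units; beyond the scatter) from compound 3 to compound 4, at least 4.3-fold (0.63 log units) apart, beyond the scatter of two such steps.
This does not show what sets the two steps apart, since the entering methoxy in compound 4 is ortho to two methoxy groups and para to a large group while in compound 2 it is only para to a large group, and two pairs cannot separate that difference in place from the difference in core.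

Still open, on these data alone, is whether a lone methoxy group para to a large group on the core of compound 3 would give a step closer to the one on the core of compound 1. Also open, as far as these compounds go, is whether a hydroxy group or an amine in the place of the entering methoxy on compound 3 would follow the same course in this assay.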